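A few compounds are considered here, and "the series" means these few. Any claim that something is new, unique, unknown or untested is made for them only; others in the source may bear on it.

Of the compounds shown here, three have so far been tested in an ADME assay on RAW264.7 cells (Mus musculus) for cytotoxicity, read by MTT assay, with a stated time of 24 h, tested at 5 ug/mL; on this read-out lower numbers stand for a stronger effect and higher numbers for a weaker effect at the one concentration tested. Compound 1 `COc1ccc(CCC(=O)c2cccc(O)c2)cc1` gives 94.5% in this assay. Compound 2 `COc1ccc(CCCc2ccc(OC)cc2OC)c(O)c1` gives 91.5%, and compound 3 `COc1ccc(C(=O)CCc2ccc(OC)cc2OC)c(O)c1` gives 87.4%. Compound 3 shows the lowest of these three numbers, yet the gaps to compound 2 and to compound 1 both lie within the usual scatter of repeated measurements, so none of the three can be set apart from the others on the strength of its number alone.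

The next compound, compound 4 `COc1ccc(CCC(=O)c2ccc(OC)cc2O)cc1`, differs from compound 3 in one place: hydrogen in place of methoxy on an aromatic carbon. Among the compounds with values here, no pair of measured compounds differs in this single way, so there is no measured step to lean on. Since all three measured compounds sit close together, with compound 3 at 87.4%, the step of a number 2.6 percentage points higher from compound 3 to compound 4 (within the scatter) is expected to be small and not to reach beyond the scatter in either direction. Compound 4 is therefore estimated to give 90% in this assay, most likely falling between 80% and 100%.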

Compound 4, a percentage reported as activity, at one concentration (the size of the read-out at that concentration, not a potency): 92.3%
Compound 4: middle estimate off by 2.3 percentage points, on the low side; the range from low to high includes it.
By their numbers in this assay, from the lowest: compounds 3, 2, 4 and 1 (each within the scatter of the next).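

Within the data shown here, the swap of methoxy for hydrogen on this aromatic carbon, ortho to a large group, is the first single change that can be read in this assay, and it gives a number 4.9 percentage points higher from compound 3 to compound 4 (within the scatter). At this place, then, the methoxy group can give way to hydrogen without the number leaving the scatter, so this change does not set compound 3 and compound 4 apart. No measured information here bears on why the result came out this way.

The compounds shown leave open whether another group at this same place, such as an amine, a carboxylic acid or a longer chain like butoxy, would also stay within the scatter. They also leave open whether the same swap at the other methoxy groups of the shared core would give a similar step.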